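Compound 4 in this assay: a prediction from three limits

This account rests on a few compounds, and the source may have more. Where it says the series, first, only, none or still open, it means among the compounds named here.

Compound 3, `Cc1cc(OCC(=O)[C@H](CC(=O)O)NC(=O)[C@@H](NC(=O)COc2cccc3ccccc23)C(C)C)nc(C)n1`, is one of three close relatives tested in a functional assay on Jurkat cells (Homo sapiens) for inhibition; a lower number here means a stronger inhibitor, a higher number a weaker inhibitor. In this assay compound 3 gives only a limit, > 200000 nM, and no number. Its two neighbours differ from it at the same place on the chain. Compound 1, `CC(C)[C@H](NC(=O)COc1cccc2ccccc12)C(=O)N[C@@H](CC(=O)O)C(=O)CSc1ncc[nH]1`, likewise reaches only a limit in this assay, > 200000 nM. Compound 2, `Cc1nnc(SCC(=O)[C@H](CC(=O)O)NC(=O)[C@@H](NC(=O)COc2cccc3ccccc23)C(C)C)s1`, gives 190000 nM in this assay. The steps show an at least 1.0-fold lower number from compound 1 to compound 2 (0.02 log units; that floor lies within the scatter), an at least 1.0-fold higher number from compound 2 to compound 3 (0.02 log units; that floor lies within the scatter) and a step that the two limits leave unreadable from compound 1 to compound 3, so nothing beyond the scatter appears anywhere among the three, and the limit of > 200000 nM in this assay, at which 2 of the 3 values shown sit, caps two of them.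

Compound 4, `CC(C)[C@H](NC(=O)COc1cccc2ccccc12)C(=O)N[C@@H](CC(=O)O)C(=O)COc1cc2ccccc2cn1`, carries the change isoquinolin-3-yl in place of 2,6-dimethylpyrimidin-4-yl on an oxygen on a saturated carbon at the group on the oxygen. For the measured compounds named here, no measured step touches the aryl part on that oxygen, so the only guide is the flat picture above. Compound 4 is therefore expected to show a number no higher from compound 3 to compound 4 (the limit leaves the size open), with the number again likely sitting at the limit. The estimate for compound 4 in this assay is 200000 nM, ranging from 60000 nM to 600000 nM.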

Compound 4, half-maximal inhibitory concentration: > 200000 nM
Compound 4 gave a limit, no number (the forecaster's own chance of this, stated with the estimate: 70%); the middle value sits exactly at the limit.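

In this assay, compound 4 reaches only a limit and no number, so a group with two six-membered aromatic rings, isoquinolin-3-yl, on this oxygen gives a result of the same kind as the single-ring 2,6-dimethylpyrimidin-4-yl. For the compounds shown here, the one readable step is an at least 1.0-fold higher number from compound 2 to compound 4 (0.02 log units; that floor lies within the scatter) and the steps from compound 1 and from compound 3 cannot be read. Across these sulfur- and oxygen-linked groups, the picture at this position therefore remains flat, with most results now capped: the limit of > 200000 nM in this assay, at which 3 of the 4 values shown sit.

Going by these compounds, how far compounds 1, 3 and 4 lie past that limit remains unknown, as does whether any group at this position can give a clearly lower number. The compounds shown also do not tell how a phenyl group on that oxygen, or an amine on the isoquinolin-3-yl group, would read.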